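Replacing a Nitrophenyl Arm on a Glycosylated Oxadiazole

A few compounds are considered here, and "the series" means these few. Any claim that something is new, unique, unknown or untested is made for them only; others in the source may bear on it.

Of the compounds shown here, three have been measured in an ADME assay on RAW264.7 cells (Mus musculus) for cytotoxicity, read by MTT assay, with a stated time of 48 h; a lower number here means that less compound is tolerated, a higher number that more compound is tolerated. Compound 1 `CC(=O)OC[C@H]1O[C@H](OC[C@H](Cn2cc(COc3ccc(-c4noc(NC5CCCCC5)n4)cc3)nn2)OC(C)=O)C=C[C@@H]1OC(C)=O` gives 33.3 ug/mL, compound 2 `C#CCN(c1nc(-c2cccc([N+](=O)[O-])c2)no1)C1CCCCC1` gives 34.2 ug/mL, and compound 3 `CC(=O)OC[C@H]1O[C@H](OC[C@@H](Cn2cc(CN(c3nc(-c4ccc([N+](=O)[O-])cc4)no3)C3CCCCC3)nn2)OC(C)=O)C=C[C@@H]1OC(C)=O` gives 64.1 ug/mL. Compound 3 thus carries the highest of the three numbers, yet its gaps to compound 1 and to compound 2 both lie within the scatter, so no ordering among the three can be claimed. Compound 4 `CC(=O)OC[C@H]1O[C@H](OC[C@@H](Cn2cc(CN(c3nc(-c4cccc(C)c4)no3)C3CCCCC3)nn2)OC(C)=O)C=C[C@@H]1OC(C)=O` differs from compound 3 in one place: 3-methylphenyl in place of 4-nitrophenyl on an aromatic carbon. Among the measured compounds shown here, no measured pair shows this same change, so nothing here fixes its effect in this assay. The expected step is a 1.1-fold lower number from compound 3 to compound 4 (0.03 log units; within the scatter), nothing beyond the scatter in either direction. Compound 4 is accordingly estimated at 60 ug/mL, with a range from 30 ug/mL to 120 ug/mL.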

Compound 4, half-maximal cytotoxic concentration: 46.4 ug/mL
Compound 4: the middle estimate sits 1.3-fold (0.11 log units) above what was measured; the range from low to high includes it.
By their numbers in this assay, from the lowest: compounds 1, 2, 4 and 3 (each within the scatter of the next).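

This first matched pair at the aromatic carbon between two ring nitrogen atoms shows that, in this assay, 3-methylphenyl in place of 4-nitrophenyl gives a 1.4-fold lower number from compound 3 to compound 4 (0.14 log units; within the scatter) even though the entering group has 0 hydrogen-bond acceptors and the leaving one has 2. At this position, then, this one exchange moves the number no further than the scatter. No available evidence bears on why this is so.
Among the compounds shown here, the single pair cannot separate the exchange of nitro for methyl from the shift in where the group sits on the phenyl ring. From the compounds shown here alone, whether an amine, a carboxylic acid or a longer chain on that phenyl ring would give a step beyond the scatter remains open.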